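A few compounds are considered here, and "the series" means these few. Any claim that something is new, unique, unknown or untested is made for them only; others in the source may bear on it.

For the measured compounds named here, in a functional assay on DU-145 cells (Homo sapiens) for inhibition, read by trypan blue exclusion, with a stated time of 96 h (on this read-out lower numbers stand for stronger inhibition of growth and higher numbers for weaker inhibition of growth), compound 2 `O=C(/C(=C\c1ccc(Br)cc1)Sc1ccc(Br)cc1)c1ccc(Br)cc1` gives 1000 nM and is the lower of the two numbers so far, while compound 1 `COc1ccc(/C=C(/Sc2ccc(Br)cc2)C(=O)c2ccc(Br)cc2)cc1` gives 25000 nM as its only neighbour. Compound 3 `O=C(/C(=C\c1ccc(Oc2ccccc2)cc1)Sc1ccc(Br)cc1)c1ccc(Br)cc1` follows from phenoxy in place of bromo on an aromatic carbon as phenoxy in place of bromo on an aromatic carbon. Going by the values given here, one measured step bears on this, the large 25-fold lower number from compound 1 to compound 2 (1.40 log units; beyond the scatter) for bromo in place of methoxy on an aromatic carbon. Phenoxy, like the methoxy of compound 1 (25000 nM) is joined through oxygen, so a partial return towards higher numbers is expected in this assay here. The expected step is a 3.0-fold higher number from compound 2 to compound 3 (0.48 log units; beyond the scatter) by estimate alone. For compound 3 the estimated value is 3000 nM with an expected range from 600 nM to 15000 nM overall.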

Compound 3, concentration for 50% growth inhibition: 50000 nM
Compound 3: the middle estimate sits 17-fold (1.22 log units) below what was measured; measured number above the stated range.
By their numbers in this assay, from the lowest: compound 2; then compounds 1 and 3 (each within the scatter of the next).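

In this assay, phenoxy in place of bromo on this aromatic carbon gives a 50-fold higher number from compound 2 to compound 3 (1.70 log units; beyond the scatter), so the low number of compound 2 does not survive this larger change. Phenyl in place of methyl on the oxygen gives a 2.0-fold higher number from compound 1 to compound 3 (0.30 log units; within the scatter), which places both oxygen-linked groups on the same high level and shows that the added aromatic ring does not recover the number. No measured data here explain the loss.

From the compounds shown here alone, it remains open whether the low number is specific to bromo or would also hold for chloro, methyl or an amine at this position.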